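The source may report more compounds than this note shows. Statements on the series, on what has been measured and on what is new or still open speak of the compounds shown alone.

In a functional assay on NCI-H1299 cells (Homo sapiens) for inhibition, read by CCK-8 assay, with a stated time of 72 h, tested at 10 uM (a lower number here means less inhibition of growth, a higher number more inhibition of growth at the concentration tested), compound 1 `CN(C)C(=O)c1cc2cnc(Nc3ccc(N)cn3)nc2n1C1CCCC1` gives 82.1%, compound 2 `CN(C)C(=O)c1cc2cnc(Nc3ccc(NC(=O)C4(C(=O)Nc5ccc(Cl)cc5)CC4)cc3)nc2n1C1CCCC1` gives 88.6% and compound 3 `CN(C)C(=O)c1cc2cnc(Nc3ccc(NC(=O)C4(C(=O)Nc5cccc(F)c5)CC4)cc3)nc2n1C1CCCC1` gives 87%. Compound 3 thus lies within the scatter of both others, and the three cannot be ranked. Compound 4 `CN(C)C(=O)c1cc2cnc(Nc3ccc(NC(=O)C4(C(=O)Nc5ccccc5F)CC4)cc3)nc2n1C1CCCC1` differs from compound 3 in one group: 2-fluorophenyl in place of 3-fluorophenyl on an amide-type nitrogen. In words, this is 2-fluorophenyl in place of 3-fluorophenyl on an amide-type nitrogen. For the measured compounds named here, the one measured step at that place, 3-fluorophenyl in place of 4-chlorophenyl, is a number 1.6 percentage points lower from compound 2 to compound 3 (within the scatter). Going by the values given here, no measured compound carries the 2-fluorophenyl group, so this assay is expected to show no step beyond the scatter, in either direction. The estimated step is a number 2 percentage points lower from compound 3 to compound 4 (within the scatter). For compound 4 the expected value is 85%, with an estimated range of 74% to 92%.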

Compound 4, percent growth inhibition at one concentration: 89.6%
Estimate against measurement, compound 4: 4.6 percentage points below, within the range that was stated.
By their numbers in this assay, from the lowest: compounds 1, 3, 2 and 4 (each within the scatter of the next).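

Placing 2-fluorophenyl on the amide-type nitrogen in this assay gives a number 2.6 percentage points higher from compound 3 to compound 4 (within the scatter), and setting it against 4-chlorophenyl gives a number 1 percentage points higher from compound 2 to compound 4 (within the scatter). Moving the fluorine around the phenyl ring, or exchanging a chlorine-bearing phenyl for a fluorine-bearing one, therefore produces no readable change at this place. No evidence is available to explain this result.

The compounds shown leave open whether a group without a phenyl ring, such as methyl, would also stay within the scatter. The same question remains for a phenyl ring carrying a carboxylic acid or an amine.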